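Ring fusion replaces dimethylpiperazine on a sulfonamide quinoline series

A few compounds are considered here, and "the series" means these few. Any claim that something is new, unique, unknown or untested is made for them only; others in the source may bear on it.

Compound 1 `Cc1c(S(=O)(=O)Nc2ccc3nccc(N4C[C@@H](C)NC[C@@H]4C)c3c2)sc2ccc(Cl)cc12`: 31.6 nM
Compound 2 `Cc1c(S(=O)(=O)Nc2ccc3nccc(N4C[C@@H](C)N[C@@H](C)C4)c3c2)sc2ccc(Cl)cc12`: 5.01 nM

In an assay on isolated protein for binding affinity to 5-hydroxytryptamine receptor 6 (Homo sapiens) (on this read-out lower numbers stand for stronger inhibition and higher numbers for weaker inhibition), compound 2 holds the lowest of the two numbers, with compound 1 the nearest to it. Among the compounds with values here, the one step measured is a 6.3-fold lower number from compound 1 to compound 2 (0.80 log units; beyond the scatter), a change only in where the two methyl groups sit. Compound 3 `Cc1c(S(=O)(=O)Nc2ccc3nccc(N4CCN5CCC[C@H]5C4)c3c2)sc2ccc(Cl)cc12` carries a group of 9 heavy atoms (7 carbon, 2 nitrogen; one five-membered non-aromatic ring with 1 hetero atom, one six-membered non-aromatic ring with 2 hetero atoms) in place of a group of 8 heavy atoms (6 carbon, 2 nitrogen; one six-membered non-aromatic ring with 2 hetero atoms), on an aromatic carbon. That single step bears on it only loosely, since the donor now disappears and a ring is added, so a modest loss beyond the scatter is expected. Compound 3 is estimated at 12 nM, within 3 nM to 50 nM, an expected step of a 2.4-fold higher number from compound 2 to compound 3 (0.38 log units; beyond the scatter).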

Compound 3, inhibition constant: 2 nM
The estimate for compound 3 lay 6.0-fold (0.78 log units) above the measured number; the measured number lies below the stated range.
By their numbers in this assay, from the lowest: compound 3; then compound 2; then compound 1.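

In this assay, the aromatic carbon opposite the ring nitrogen takes the group with one five-membered and one six-membered non-aromatic ring with a gain, not a loss: a 2.5-fold lower number from compound 2 to compound 3 (0.40 log units; beyond the scatter), and a 16-fold lower number from compound 1 to compound 3 (1.20 log units; beyond the scatter). Among these compounds, then, a low number here does not require the hydrogen-bond donor of the 3,5-dimethylpiperazin-1-yl group. Nothing shown accounts for this gain.

As far as these compounds go, it remains open whether the gain follows the added five-membered ring or the lost donor, which a 4-methylpiperazin-1-yl group at this position could help separate. From the compounds shown here alone, how the opposite configuration at the remaining stereocentre would read also stays open.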